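The compounds below may be only part of what the source reports. "The series", "measured", "known", "first", "only" and "open" are said of these compounds alone.

Of the compounds shown here, three built on one shared core have been tested in a functional assay on HepG2 cells (Homo sapiens) for antiproliferative activity, read by MTT assay, with a stated time of 48 h; a lower number here means a stronger inhibitor, a higher number a weaker inhibitor. Compound 1 `N#CC1=C(N)Oc2c(c3nc4ccccc4nc3c3ccccc23)C12C(=O)N(Cc1cnnn1-c1ccc(Cl)cc1)c1ccccc12` gives > 50000 nM, which is a limit of the assay rather than a number. Compound 2 `N#CC1=C(N)Oc2c(c3nc4ccccc4nc3c3ccccc23)C12C(=O)N(Cc1cnnn1-c1ccc(Br)cc1)c1ccccc12` gives > 50000 nM, also a limit, so its standing is described only by the limit of > 50000 nM in this assay, at which 2 of the 3 values shown sit. Compound 3 `N#CC1=C(N)Oc2c(c3nc4ccccc4nc3c3ccccc23)C12C(=O)N(Cc1cnnn1-c1cccc(S(N)(=O)=O)c1)c1ccccc12` gives 21500 nM. The step that the two limits leave unreadable from compound 1 to compound 2 cannot be sized, while an at least 2.3-fold lower number from compound 1 to compound 3 (0.36 log units; beyond the scatter) and an at least 2.3-fold lower number from compound 2 to compound 3 (0.36 log units; beyond the scatter) each give a lower number. Compound 4 `N#CC1=C(N)Oc2c(c3nc4ccccc4nc3c3ccccc23)C12C(=O)N(Cc1cnnn1-c1ccc(Cl)c(Cl)c1)c1ccccc12` carries the change (3,4-dichlorophenyl in place of 4-bromophenyl on an aromatic nitrogen). Among the measured compounds shown here, the only comparable measured step, a step that the two limits leave unreadable from compound 1 to compound 2, is unreadable, so the expected step is a step that the limit leaves unreadable from compound 2 to compound 4, nothing beyond the scatter. Compound 4 is therefore estimated at 60000 nM, within a range from 20000 nM to 200000 nM.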

Compound 4, half-maximal inhibitory concentration: > 50000 nM
Compound 4: a limit, no number; the forecaster's own chance of this, stated with the estimate: 70%; the middle value does not contradict the limit.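

In this assay, carrying two chlorines on this phenyl ring, as 3,4-dichlorophenyl in compound 4, still gives only a limit and not a number, as with the single halogens of compound 1 and compound 2: the limit of > 50000 nM in this assay, at which 3 of the 4 values shown sit.

The steps among these three compounds cannot be read. The 3-sulfamoylphenyl group remains the only one here with a measured number, and replacing it gives an at least 2.3-fold higher number from compound 3 to compound 4 (0.36 log units; beyond the scatter).

Still open, on these data alone, is whether an amine or a carboxylic acid on this phenyl ring would also give a measured number, and whether the sulfamoyl group would do so elsewhere on the ring.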